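Isobutyl in Place of 4-Fluorophenyl, Measured Once, Expected Again

The source may hold more compounds than are shown below. What is called first, only, known or untested is meant among the compounds shown, and "the series" means these compounds.

Compound 1 `Fc1ccc(Cc2ccc3c(NCCCNCc4ccco4)ccnc3c2)cc1` and compound 2 `CC(C)CCc1ccc2c(NCCCNCc3ccco3)ccnc2c1` differ in a single place: isobutyl in place of 4-fluorophenyl on a saturated chain carbon bound to an aromatic carbon. In an ADME assay on HepG2 cells (Homo sapiens) for cytotoxicity, read by luminescence, CellTiter-Glo and ATP content, with a stated time of 72 h (on this read-out lower numbers stand for an effect already at smaller amounts and higher numbers for an effect only at larger amounts of compound), compound 1 gives 5600 nM, and compound 2 gives 11200 nM, so that a 2.0-fold higher number from compound 1 to compound 2 (0.30 log units; within the scatter). Compound 3 `COc1cccc(CNCCCNc2ccnc3cc(Cc4ccc(F)cc4)ccc23)c1O` differs from compound 1 elsewhere, and this difference between the two cores is 2-hydroxy-3-methoxyphenyl in place of furan-2-yl on a saturated chain carbon bound to an amine nitrogen. In this assay compound 3 gives 4780 nM, and a 1.2-fold lower number from compound 1 to compound 3 (0.07 log units; within the scatter). Compound 4 `COc1cccc(CNCCCNc2ccnc3cc(CCC(C)C)ccc23)c1O` has not yet been measured in this assay. It stands to compound 3 as compound 2 stands to compound 1: isobutyl in place of 4-fluorophenyl on a saturated chain carbon bound to an aromatic carbon. The place of the change is the same in both pairs, word for word, so the two changes are the same, made on cores that differ as already told. For compound 4 in this assay a step of a 2.0-fold higher number from compound 3 to compound 4 (0.30 log units; within the scatter) is expected, because the same change in the earlier pair gave a 2.0-fold higher number from compound 1 to compound 2 (0.30 log units; within the scatter), a step that lay within the usual scatter. Compound 4 is therefore estimated at 9500 nM. The expected range for compound 4 runs from 4000 nM to 22000 nM.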

Compound 4, half-maximal effective concentration: 5390 nM
For compound 4 the middle estimate is 1.8-fold (0.25 log units) above the measured one; the measured number falls inside the stated range.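

Isobutyl in place of 4-fluorophenyl gives a 1.1-fold higher number from compound 3 to compound 4 (0.05 log units; within the scatter) in this assay, and set beside its earlier step, this change carries over to the second core: the same change on two cores in this assay, a 2.0-fold higher number (0.30 log units; within the scatter) from compound 1 to compound 2 and a 1.1-fold higher number (0.05 log units; within the scatter) from compound 3 to compound 4, 1.8-fold (0.25 log units) apart, within the scatter of two such steps. The other change, 2-hydroxy-3-methoxyphenyl in place of furan-2-yl, gives a 2.1-fold lower number from compound 2 to compound 4 (0.32 log units; beyond the scatter), and it too stays in line with its earlier step: the same change on two cores in this assay, a 1.2-fold lower number (0.07 log units; within the scatter) from compound 1 to compound 3 and a 2.1-fold lower number (0.32 log units; beyond the scatter) from compound 2 to compound 4, 1.8-fold (0.25 log units) apart, within the scatter of two such steps. Going by these compounds alone, this shows that neither change depends on the core by more than the scatter in these four compounds, but it rests on only two cores for each change and does not show that the steps are identical or that they would hold on any further core.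

The compounds shown leave open whether the same agreement holds for a longer chain or a cyclohexyl group in place of isobutyl, or for a group carrying an amine or a carboxylic acid in place of 2-hydroxy-3-methoxyphenyl. They also leave open how these changes behave in any read-out other than this assay.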